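The compounds below may be only part of what the source reports. "The series", "measured", "known", "first", "only" and "open" are said of these compounds alone.

In a functional assay on SAOS-2 cells (Homo sapiens) for antiproliferative activity, read by MTT assay, with a stated time of 72 h (a lower number here means a stronger inhibitor, a higher number a weaker inhibitor), the three measured compounds gave these numbers:

Compound 1 `CCOC1=C(C(=O)c2ccccc2)C(c2ccc(Br)cc2)N(CCCn2ccnc2)C1=O` gives 31700 nM.
Compound 2 `O=C(C1=C(Nc2ccccc2)C(=O)N(CCCn2ccnc2)C1c1ccc(Br)cc1)c1ccccc1` gives 24400 nM.
Compound 3 `O=C(C1=C(Nc2ccc(I)cc2)C(=O)N(CCCn2ccnc2)C1c1ccc(Br)cc1)c1ccccc1` gives 23400 nM.

Compound 3 holds the lowest of the three numbers, but only barely: the step of a 1.0-fold lower number from compound 2 to compound 3 (0.02 log units; within the scatter) and the step of a 1.4-fold lower number from compound 1 to compound 3 (0.13 log units; within the scatter) both fall within the scatter of repeated measurements, so the three compounds cannot be told apart on these numbers.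

Compound 4 `O=C(C1=C(Nc2ccccc2Br)C(=O)N(CCCn2ccnc2)C1c1ccc(Br)cc1)c1ccccc1` is the next compound in the series. The change from compound 3 is this: 2-bromophenyl in place of 4-iodophenyl on an amine nitrogen. The ring carried on the amine nitrogen keeps its size and its count of heavy atoms; what changes is which halogen it carries and where the halogen sits on that ring.

Going by the values given here, two measured steps bear on this change. The step of a 1.0-fold lower number from compound 2 to compound 3 (0.02 log units; within the scatter) shows that putting a halogen onto that ring made no difference beyond the scatter, and the step of a 1.3-fold lower number from compound 1 to compound 2 (0.11 log units; within the scatter) shows that the whole anilino group in place of ethoxy made none either. Among the compounds with values here, nothing measured so far suggests that this part of the molecule moves the number in this assay. The expected step is therefore a 1.0-fold higher number from compound 3 to compound 4 (0.01 log units; within the scatter), no larger than the scatter and with no clear direction. Compound 4 is estimated at 24000 nM, with a range from 12000 nM to 48000 nM.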

Compound 4, half-maximal inhibitory concentration: 19600 nM
The estimate for compound 4 lay 1.2-fold (0.09 log units) above the measured number; measured number inside the range.
By their numbers in this assay, from the lowest: compounds 4, 3, 2 and 1 (each within the scatter of the next).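

In this assay, going by these compounds alone, 2-bromophenyl in place of 4-iodophenyl on the amine nitrogen gives a 1.2-fold lower number from compound 3 to compound 4 (0.08 log units; within the scatter) and is the first step in which both the halogen and its place on the ring differ, yet compound 3 and compound 4 cannot be told apart. Bromo in place of hydrogen on the aromatic ring gives a 1.2-fold lower number from compound 2 to compound 4 (0.10 log units; within the scatter) and so shows, as the iodo compound did, that a halogen on this ring does not separate a compound from the plain anilino compound 2. Even (2-bromophenyl)amino in place of ethoxy, with a 1.6-fold lower number from compound 1 to compound 4 (0.21 log units; within the scatter) as the largest step so far, stays within the scatter, so all four compounds remain one group on these numbers; no further data here help to interpret them.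

The compounds shown carry only hydrogen, iodo or bromo on this ring, so it stays open whether a carboxylic acid or an amine there would give a step beyond the scatter. The same question stands for the shared core, which all four compounds keep unchanged.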